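Compound 4: a cyclic amine replaces the open chain

The source may hold more compounds than are shown below. What is called first, only, known or untested is meant among the compounds shown, and "the series" means these compounds.

Compound 3 `CNCCNc1c(F)cc2c(=O)c(C(=O)O)cn(Cc3ccc(-c4ccccc4)cc3)c2c1OC` carries the (2-(methylamino)ethyl)amino group on the shared core. In an assay on isolated protein for inhibition of DNA topoisomerase 1 (Homo sapiens), with a stated time of 15 min (a higher number here means a weaker inhibitor, a lower number a stronger inhibitor), compound 3 returns only a limit, > 200000 nM. Compound 1 `COc1c(NCCN)c(F)cc2c(=O)c(C(=O)O)cn(Cc3ccc(-c4ccccc4)cc3)c12` carries the (2-aminoethyl)amino group on the same core. In this assay compound 1 likewise returns a limit, > 200000 nM. Compound 2 `COc1c(N2CC[C@@H](CO)C2)c(F)cc2c(=O)c(C(=O)O)cn(Cc3ccc(-c4ccccc4)cc3)c12` carries 3-(hydroxymethyl)pyrrolidin-1-yl. In this assay compound 2 also returns a limit, > 200000 nM. The steps a step that the two limits leave unreadable from compound 1 to compound 2, a step that the two limits leave unreadable from compound 1 to compound 3 and a step that the two limits leave unreadable from compound 2 to compound 3 are therefore all unreadable, and the one firm point in the set is the limit of > 200000 nM in this assay, at which 3 of the 3 values shown sit. Compound 3 thus stands on the assay floor together with the other two and cannot be ranked against either.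

Compound 4 `CN[C@@H]1CCN(c2c(F)cc3c(=O)c(C(=O)O)cn(Cc4ccc(-c5ccccc5)cc4)c3c2OC)C1` is the next member of the series: 3-(methylamino)pyrrolidin-1-yl in place of (2-(methylamino)ethyl)amino on an aromatic carbon. The closest comparison, open chain against pyrrolidine, is a step that the two limits leave unreadable from compound 1 to compound 2, which gives no readable size. Within the data shown here, no measured step points to a gain large enough to lift the new compound off the floor. Compound 4 is expected to remain at the limit, about 250000 nM, with a range from 100000 nM to 1000000 nM. The step expected on this basis, a step that the limit leaves unreadable from compound 3 to compound 4, is no change beyond the scatter.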

Compound 4, half-maximal inhibitory concentration: 57700 nM
For compound 4 the middle estimate is 4.3-fold (0.64 log units) above the measured one; measured number below the stated range.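

In this assay, among these compounds, 3-(methylamino)pyrrolidin-1-yl on this aromatic carbon, ortho to a fluoro group and ortho to a methoxy group, gives the first readable value, with an at least 3.4-fold lower number from compound 3 to compound 4 (0.53 log units; beyond the scatter) and an at least 3.4-fold lower number from compound 1 to compound 4 (0.53 log units; beyond the scatter). The ring alone does not account for this, as compound 2 also carries a pyrrolidine on this carbon, and methylamino in place of hydroxymethyl on a saturated ring carbon gives an at least 3.4-fold lower number from compound 2 to compound 4 (0.53 log units; beyond the scatter). Among the compounds shown, neither the pyrrolidine with hydroxymethyl nor either open chain gives a readable value, the steps among compound 1, compound 2 and compound 3 still cannot be read, and compound 4 alone stands clear of the limit: the limit of > 200000 nM in this assay, at which 3 of the 4 values shown sit.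

Open, going by these compounds, is whether a primary amino group or a dimethylamino group on the same ring carbon would read like methylamino, and whether the opposite configuration at the stereocentre would change the value. Also open, on these data alone, is how a piperidine or an azetidine in place of the pyrrolidine would read on this aromatic carbon.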